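The source may report more compounds than this note shows. Statements on the series, on what has been measured and on what is new or still open speak of the compounds shown alone.

Of the compounds shown here, three built on a shared core have so far been tested in an ADME assay on HepG2 2.2.15 cells (Homo sapiens) for cytotoxicity, read by MTT assay, with stated times of 3 days and 7 days; on this read-out higher numbers stand for lower toxicity in this test and lower numbers for higher toxicity in this test. Compound 1 `O=C(NCc1ccc(Cl)cc1)c1cc(-c2ccccc2)nc2ccccc12` gives a result that is only a limit of the test, > 20000 nM. Compound 3 `O=C(OCc1ccc(Cl)cc1)c1cc(-c2ccccc2)nc2ccccc12`, in which (4-chlorobenzyl)oxy stands in place of (4-chlorobenzyl)amino on a carbonyl carbon, likewise gives only a limit, > 20000 nM. Both ends being limits, the step that the two limits leave unreadable from compound 1 to compound 3 cannot be read. Compound 2 `CC(C)Cc1ccc(-c2cc(C(=O)N3CCC(Cc4ccccc4)CC3)c3ccccc3n2)cc1` is the starting point of the present step; in this assay compound 2 also gives only a limit, > 20000 nM. For the measured compounds named here, compound 2 thus stands where every other compound stands, at the limit of > 20000 nM in this assay, at which 3 of the 3 values shown sit, and no compound shows an actual number.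

Compound 4 `O=C(c1cc(-c2ccsc2Cl)nc2ccccc12)N1CCC(Cc2ccccc2)CC1` has not yet been measured. It differs from compound 2 in one place: 2-chlorothiophen-3-yl in place of 4-isobutylphenyl on an aromatic carbon. Going by the values given here, no measured step touches this change; the single step that exists, from compound 1 to compound 3, sits at a different place on the core and is itself unreadable. With every value shown resting at the same limit, the step that the limit leaves unreadable from compound 2 to compound 4 is expected to be none beyond the scatter, and compound 4 is expected once more to reach only the limit. Compound 4 is therefore estimated at 25000 nM, with a range from 10000 nM to 60000 nM.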

Compound 4, half-maximal cytotoxic concentration: > 20000 nM
Compound 4 was reported as a limit; the forecaster's own chance of this, stated with the estimate: 85%; the middle value lies beyond the limit too.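

Compound 2 and compound 4 both give only a limit in this assay, so the step between them cannot be read. All the compounds shown rest at the same limit: the limit of > 20000 nM in this assay, at which 4 of the 4 values shown sit.

The compounds shown leave open at what concentration any of them would harm these cells, and whether any change on the shared core alters that concentration.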